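Ester to amide swap at the carbonyl in the thiophene series

The source may hold more compounds than are shown below. What is called first, only, known or untested is meant among the compounds shown, and "the series" means these compounds.

Measured compounds:
compound 1 `CCOC(=O)c1cscc1-c1ccc(OC)c(OC)c1`: 3%
compound 2 `CCOC(=O)c1c(-c2ccc(OC)c(OC)c2)csc1NC`: 32%
compound 3 `COc1ccc(-c2csc(N)c2C(=O)OCc2ccccc2)cc1OC`: 100%

In an assay on isolated protein for inhibition of protein kinase C zeta type (Homo sapiens), with stated times of 1 h and 2.5 min, tested at 30 uM (on this read-out higher numbers stand for more inhibition at the one concentration tested (going by the name of the read-out) and lower numbers for less inhibition), compound 3 gives the highest of the three numbers; its nearest neighbour is compound 2, which gives 32%, and compound 1 lies furthest away with 3%. Among the measured compounds shown here, the only single-point step measured so far is a number 29 percentage points higher from compound 1 to compound 2 (beyond the scatter), a modest gain from adding methylamino.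

Compound 4 `CCNC(=O)c1c(-c2ccc(OC)c(OC)c2)csc1N` is not yet measured. It differs from compound 3 by ethylamino in place of benzyloxy on a carbonyl carbon. For the measured compounds named here, no measured pair changes the carbonyl substituent, so the step from compound 3 to compound 4 has no direct precedent; compound 2 and compound 3 differ in two places at once and cannot separate the two changes. The expectation is therefore wide: a drop from the value of compound 3 is expected, estimated as a number 50 percentage points lower from compound 3 to compound 4 (beyond the scatter), since compound 3 already sits at the top of the scale. For compound 4 in this assay the estimated value is 50%, with a range from 10% to 90%.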

Compound 4, a percentage reported as inhibition, at one concentration (the size of the read-out at that concentration, not a potency): 50%
For compound 4 middle estimate and measured number coincide at the digits printed, and the stated range covers the measured number.
By their numbers in this assay, from the lowest: compound 1; then compound 2; then compound 4; then compound 3.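

In this assay, the substituent on the carbonyl carbon is now shown to matter: ethylamino in place of benzyloxy gives a number 50 percentage points lower from compound 3 to compound 4 (beyond the scatter), the first direct reading at this position. Among the compounds shown here, the step is larger than the one earlier single change, a number 29 percentage points higher from compound 1 to compound 2 (beyond the scatter), though the two steps concern different places on the shared core. The change removes the six-membered aromatic ring, shortens the substituent from 8 heavy atoms to 3 and brings in a hydrogen-bond donor all at once, and no measurement on hand accounts for the loss.

Which of these differences carries the step stays open. A benzylamino group on the same carbonyl carbon would keep the aromatic ring while exchanging the oxygen for nitrogen, and a longer chain on the amide nitrogen would test the ring-free side.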